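The compounds below may be only part of what the source reports. "The series", "measured", "known", "first", "only" and "open" are said of these compounds alone.

Measured compounds:
- compound 1, `Cc1cc(-n2ccc(N3CCNC3=O)n2)c2c(n1)N(c1ccc(C#N)cc1C)CC2`: 67.6 nM
- compound 2, `COc1ccc(N2CCc3c(-n4ccc(N5CCOC5=O)n4)cc(C)nc32)c(C)c1`: 1950 nM
- compound 3, `COc1ccc(N2CCc3c(-n4ccc(N5CCCC5=O)n4)cc(C)nc32)c(C)c1`: 123 nM

In an assay on CHO cells for displacement of a labelled ligand from corticotropin-releasing factor receptor 1 (Homo sapiens) (a higher number here means a weaker inhibitor, a lower number a stronger inhibitor), compound 1 has the lowest of the three numbers. Its nearest neighbour is compound 3, whose value lies within the scatter of repeated measurement, so no order between these two can be stated. Compound 2 stands furthest away, beyond the scatter. Among the compounds with values here, the one step between measured compounds that differ in a single place is a 16-fold lower number from compound 2 to compound 3 (1.20 log units; beyond the scatter); it concerns the ring attached to the pyrazole and not the aryl group on the core nitrogen.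

Compound 4, `CCc1cc(C#N)ccc1N1CCc2c(-n3ccc(N4CCNC4=O)n3)cc(C)nc21`, is not yet measured. It differs from compound 1 by methyl in place of hydrogen on a saturated chain carbon bound to an aromatic carbon. Within the data shown here, no measured pair in this set bears on that change: the aryl group on the core nitrogen varies between compound 1 and compounds 2 and 3 in more than one place, so its effect cannot be separated. Among the measured compounds shown here, the single large step concerns a different part of the molecule. Without a relevant step the expectation is a change no larger than the scatter, in either direction, and the estimated step is a 1.0-fold higher number from compound 1 to compound 4 (0.02 log units; within the scatter). For compound 4 the value in this assay is therefore expected at 70 nM, with a range from 30 nM to 170 nM.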

Compound 4, half-maximal inhibitory concentration: 50.1 nM
The estimate for compound 4 lay 1.4-fold (0.15 log units) above the measured number; low and high end bracket the measured number.
By their numbers in this assay, from the lowest: compounds 4, 1 and 3 (each within the scatter of the next, the first and the last beyond it); then compound 2.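

In this assay the change from 4-cyano-2-methylphenyl to 4-cyano-2-ethylphenyl gives a 1.3-fold lower number from compound 1 to compound 4 (0.13 log units; within the scatter) and this step lies within the scatter, so no order between the two compounds can be stated. Within the data shown here, it is the first single-place step in the set on the aryl group at the core nitrogen, since the earlier compounds differed there only together with a change elsewhere. At this place, on a saturated chain carbon bound to an aromatic carbon, methyl to ethyl therefore leaves the number within the scatter, and nothing measured here gives a reason for this result.

Going by these compounds, this single step says nothing about a longer chain such as propyl, a branched isopropyl group or a cyclopropyl ring at the same place, so how far the tolerance extends remains open. Also open, on these data alone, is whether the large step seen on the methoxy-bearing aryl series, a 16-fold lower number from compound 2 to compound 3 (1.20 log units; beyond the scatter), carries over to the nitrile-bearing compounds, and how the aryl groups compare directly, as the remaining pairs differ in more than one place and cannot be read.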